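The source may hold more compounds than are shown below. What is called first, only, known or untested is meant among the compounds shown, and "the series" means these compounds.

Measured compounds:
Compound 1, `CCOC(=O)C1=C(C)NC(=O)NC1C1CCCC1`: in an assay on cells for displacement of a labelled ligand from adenosine receptor A1 (Homo sapiens), with a stated time of 60 min, tested at 1 uM (a higher number here means more inhibition at the concentration tested (going by the name of the read-out), a lower number less inhibition), compound 1 gives 3%.
Compound 2, `CC1=C(C(=O)OC(C)C)[C@@H](c2ccco2)N/C(=N/C#N)N1`: in this assay compound 2 gives 2%.
Compound 3, `CCOC(=O)C1=C(C)N/C(=N\C#N)NC1c1cccs1`: in this assay compound 3 gives 26%.

Among these three, compound 3 stands highest, and its lead over each of the other two lies beyond the usual scatter: compound 1 sits a little closer to it than compound 2 does. Among the compounds with values here, no two of the measured compounds differ in only one place, so no single structural step can be read directly from the numbers; the three values show only that the compound carrying a thiophen-2-yl group has the highest number of the set.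

Compound 4, `CCOC(=O)C1=C(C)N/C(=N\C#N)NC1c1ccsc1`, has not yet been measured in this assay. It holds the same atoms as compound 3, joined differently: thiophen-3-yl in place of thiophen-2-yl on a saturated ring carbon. Nothing in the measured set tells how such a rearrangement affects the read-out, so the expected step from compound 3 to compound 4 in this assay is taken as small, a number 6 percentage points lower from compound 3 to compound 4 (within the scatter), lying within the scatter in either direction. Compound 4 is therefore estimated at 20%, with a range from 5% to 40%.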

Compound 4, a percentage reported as inhibition, at one concentration (the size of the read-out at that concentration, not a potency): 29%
The estimate for compound 4 lay 9 percentage points below the measured number, and the stated range covers the measured number.
By their numbers in this assay, from the lowest: compounds 2 and 1 (each within the scatter of the next); then compounds 3 and 4 (each within the scatter of the next).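

Within the data shown here, putting thiophen-3-yl in place of thiophen-2-yl on the saturated ring carbon gives a number 3 percentage points higher from compound 3 to compound 4 (within the scatter) in this assay and so provides the first comparison in the set that isolates one place. At this position the read-out does not separate the two thiophene attachments, so the number seen for compound 3 is not tied to thiophen-2-yl alone. Nothing available explains this result.

The compounds shown leave open how the read-out would respond to a different group on this carbon, such as phenyl or a longer alkyl chain, since only the two thiophene attachments can be compared directly. They also leave open how far the ethoxycarbonyl group and the nitrile-bearing part of the shared core contribute, as neither is varied alone.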